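A New Sulfonyl Substituent, an Unbound Fraction Still Unknown

The compounds below may be only part of what the source reports. "The series", "measured", "known", "first", "only" and "open" are said of these compounds alone.

In an ADME assay on a cell-free system (plasma, Rattus norvegicus) for protein binding (a higher number here means a larger unbound share of the compound, a lower number a smaller unbound share), compound 1 (`N#Cc1ccc(O[C@H]2CN(S(=O)(=O)c3ccccc3C#N)C[C@@]2(O)CO)cc1F`) gives 0.197 and compound 2 (`N#Cc1ccc(O[C@H]2CN(S(=O)(=O)c3ccc(Cl)cn3)C[C@@]2(O)CO)cc1F`) gives 0.18. Going by the values given here, compound 2 therefore stands within the scatter of compound 1, the only other compound measured so far. Compound 3 (`N#Cc1ccc(O[C@H]2CN(S(=O)(=O)c3ccc(C(F)(F)F)nc3)C[C@@]2(O)CO)cc1F`) keeps the shared core and differs from compound 2 in a single group: 6-(trifluoromethyl)pyridin-3-yl in place of 5-chloropyridin-2-yl on a sulfonyl sulfur. This places 6-(trifluoromethyl)pyridin-3-yl in place of 5-chloropyridin-2-yl on a sulfonyl sulfur. Among the compounds with values here, one measured step bears on this change, as it also exchanged the group on the sulfonyl sulfur: a 1.1-fold lower number from compound 1 to compound 2 (0.04 log units; within the scatter). On that single precedent, no step beyond the scatter is expected in this assay, although one step is thin evidence. The expected change is a 1.1-fold lower number from compound 2 to compound 3 (0.05 log units; within the scatter). For compound 3, the estimated unbound fraction is 0.16, within an expected range of 0.09 to 0.27.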

Compound 3, unbound fraction: 0.147
Beside the measured number, compound 3's estimate is 1.1-fold (0.04 log units) above it, within the range that was stated.
By their numbers in this assay, from the lowest: compounds 3, 2 and 1 (each within the scatter of the next).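

Placing 6-(trifluoromethyl)pyridin-3-yl on the sulfonyl sulfur in place of 5-chloropyridin-2-yl gives a 1.2-fold lower number from compound 2 to compound 3 (0.09 log units; within the scatter) in this assay. Set against the 2-cyanophenyl group, the same substituent gives a 1.3-fold lower number from compound 1 to compound 3 (0.13 log units; within the scatter) and so, across these three aromatic groups on the sulfonyl sulfur, including the one with the most heavy atoms, compounds 1, 2 and 3 all remain within the scatter of one another. No measurement is available that would explain this result.

The compounds shown carry only aromatic rings on the sulfonyl sulfur, so it remains open whether the unbound fraction would stay within the same scatter with a saturated amine or a carboxylic acid there. They also leave open whether any change elsewhere on the shared core would produce a clearer step.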